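The compounds below may be only part of what the source reports. "The series", "measured", "known", "first", "only" and "open" are said of these compounds alone.

Measured so far in a functional assay on PC-3 cells (Homo sapiens) for cytotoxicity, read by sulforhodamine B assay, with a stated time of 48 h; on this read-out higher numbers stand for weaker inhibition and lower numbers for stronger inhibition:
- compound 1 `COc1ccc(C2CC(c3cccc([N+](=O)[O-])c3)=NN2C(C)=O)cc1` gives 7830 nM
- compound 2 `CC(=O)N1N=C(c2ccco2)CC1c1ccccc1[N+](=O)[O-]` gives 19000 nM
- compound 3 `CC(=O)N1N=C(c2ccco2)CC1c1ccc(Br)cc1` gives 42100 nM

Among these three, compound 3 carries the highest number, and both gaps to it lie beyond the usual scatter, so it shows the weakest inhibition of the set. Compound 2 stands nearest to it and compound 1 furthest away.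

Compound 4 `CC(=O)N1N=C(c2ccco2)CC1c1ccc(N(C)C)cc1` is not yet measured. It differs from compound 3 in one place: dimethylamino in place of bromo on an aromatic carbon. The shared core and the other ring are unchanged. Within the data shown here, no measured pair in this set isolates that particular swap, so the size of the step has to be guessed rather than read off. The expectation is a modest move toward stronger inhibition, that is a lower number in this assay, but one that could just as well fall within the scatter. The step from compound 3 to compound 4 is estimated at a 2.1-fold lower number from compound 3 to compound 4 (0.32 log units; beyond the scatter). For compound 4 the expected value is 20000 nM, with a range from 5000 nM to 60000 nM.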

Compound 4, half-maximal inhibitory concentration: 16700 nM
Compound 4: the middle estimate sits 1.2-fold (0.08 log units) above what was measured; the measured number falls inside the stated range.
By their numbers in this assay, from the lowest: compound 1; then compounds 4 and 2 (each within the scatter of the next); then compound 3.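

In this assay, among these compounds, putting dimethylamino in place of bromo on the aromatic carbon gives a 2.5-fold lower number from compound 3 to compound 4 (0.40 log units; beyond the scatter) as the first step in this set that isolates a single change. This shows that the position para to a large group is not indifferent to what sits on it, since a modest move toward stronger inhibition appears while the shared core and the other ring stay the same. No measurement at hand bears on what lies behind this step.

One pair cannot show whether the nitrogen or the two methyl groups of dimethylamino matter more, so a plain amino group, a morpholine or a carboxylic acid at this same place remains an open comparison. As far as these compounds go, it also remains open whether the same swap would give a similar step with the other ring of compound 1.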